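This account rests on a few compounds, and the source may have more. Where it says the series, first, only, none or still open, it means among the compounds named here.

Measured compounds:
compound 1 `O=C(Nc1ccc(Cl)c(-c2nnc3c(Cl)cccn23)c1)c1ccccn1` in a functional assay on T47D cells (Homo sapiens) for antiproliferative activity, read by MTT assay, with a stated time of 72 h; a lower number here means a stronger inhibitor, a higher number a weaker inhibitor: > 100000 nM
compound 2 `O=C(Nc1ccc(Cl)c(-c2nnc3c(Cl)cccn23)c1)c1cccc(Cl)c1` in this assay: 30200 nM

Compound 1 gives only a limit of this assay and not a number (the limit of > 100000 nM in this assay, at which 1 of the 2 values shown sits). Compound 2 holds the only number shown. Among the compounds with values here, the one measured step, an at least 3.3-fold lower number from compound 1 to compound 2 (0.51 log units; beyond the scatter), exchanges the group on the carbonyl carbon and is at least modest in size.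

Compound 3 `CS(=O)(=O)c1ccc(C(=O)Nc2ccc(Cl)c(-c3nnc4c(Cl)cccn34)c2)cc1` differs from compound 2 by 4-(methylsulfonyl)phenyl in place of 3-chlorophenyl on a carbonyl carbon. The same carbonyl carbon is altered as in the measured step, but that step went from a pyridine to a phenyl and says nothing about one substituted phenyl replacing another. Within the data shown here, no measured compound carries a methylsulfonyl group. With only this thin footing, the step from compound 2 to compound 3 is expected to stay near the scatter, if anything with a somewhat higher number: a 1.5-fold higher number from compound 2 to compound 3 (0.17 log units; within the scatter). Compound 3 is therefore estimated at 45000 nM, within 12000 nM to 150000 nM.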

Compound 3, half-maximal inhibitory concentration: > 100000 nM
Compound 3 ended at the assay's limit; the forecaster's own chance of this, stated with the estimate: 30%; middle value at least 2.2-fold (0.34 log units) away from the limit.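

In this assay, replacing 3-chlorophenyl with 4-(methylsulfonyl)phenyl on the carbonyl carbon gives an at least 3.3-fold higher number from compound 2 to compound 3 (0.51 log units; beyond the scatter), so the choice among substituted phenyl groups at this position also moves the result, not only the earlier exchange of pyridin-2-yl for a phenyl group. The value of compound 3, > 100000 nM, is a limit of the assay and not a number. Compound 2 therefore remains the only compound with a number, and the step between compound 1 and compound 3 cannot be read: the limit of > 100000 nM in this assay, at which 2 of the 3 values shown sit.

The compounds shown do not separate the identity of the substituent from its place on the phenyl ring, which 4-chlorophenyl or 3-(methylsulfonyl)phenyl would address. As far as these compounds go, what an amine or a carboxylic acid on that ring would give also remains open.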